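Methylsulfanyl for methoxy on the benzyl group of a quinazoline series

A few compounds are considered here, and "the series" means these few. Any claim that something is new, unique, unknown or untested is made for them only; others in the source may bear on it.

Measured so far:
- compound 1 `CSc1nc(NCc2ccccc2)c2ccccc2n1`: in a functional assay on HT-29 cells (Homo sapiens) for cytotoxicity, read by MTT assay, with a stated time of 72 h (on this read-out lower numbers stand for stronger inhibition of growth and higher numbers for weaker inhibition of growth), compound 1 gives > 100000 nM, which is a limit of the assay.
- compound 2 `COc1ccc(CNc2nc(SC)nc3ccccc23)cc1`: in this assay compound 2 gives > 100000 nM, again a limit and not a number.

Within the data shown here, compound 2 therefore stands only on a limit; the one other value shown is a limit as well (the limit of > 100000 nM in this assay, at which 2 of the 2 values shown sit). Among the measured compounds shown here, the single measured step, a step that the two limits leave unreadable from compound 1 to compound 2, is consequently unreadable in size and direction.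

The next compound is compound 3 `CSc1ccc(CNc2nc(SC)nc3ccccc23)cc1`. Relative to compound 2 it differs by methylsulfanyl in place of methoxy on an aromatic carbon. For the measured compounds named here, no measured step bears readably on this change, since the only one available, a step that the two limits leave unreadable from compound 1 to compound 2, is hidden between two limits. With both neighbours sitting at the limit, compound 3 is expected to sit there too, most likely again reported only as a limit in this assay. For compound 3 the estimated value in this assay is 150000 nM, with an expected range from 40000 nM to 500000 nM. The expected step is therefore a step that the limit leaves unreadable from compound 2 to compound 3, no more than scatter around the limit.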

Compound 3, concentration for total growth inhibition: > 100000 nM
Compound 3 was reported as a limit (the forecaster's own chance of this, stated with the estimate: 75%); the middle value does not contradict the limit.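

Compound 3 is reported only as a limit in this assay, and no step among compound 1, compound 2 and compound 3 can be read: the limit of > 100000 nM in this assay, at which 3 of the 3 values shown sit.

The compounds shown leave open whether hydrogen, methoxy or methylsulfanyl on this aromatic carbon makes any difference in this assay.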